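From methoxy to nitro on the shared core

This account rests on a few compounds, and the source may have more. Where it says the series, first, only, none or still open, it means among the compounds named here.

In a functional assay on SGC-7901 cells (Homo sapiens) for antiproliferative activity, read by MTT assay, with a stated time of 48 h (on this read-out lower numbers stand for stronger inhibition and higher numbers for weaker inhibition), compound 1 `CC(=O)N1N=C(c2ccc(F)cc2)CC1c1ccc2c(c1)OCCO2` gives 68400 nM and compound 2 `COc1ccc(C2=NN(C(C)=O)C(c3ccc4c(c3)OCCO4)C2)cc1` gives 45800 nM so these two stand within the scatter of each other. Compound 3 `CC(=O)N1N=C(c2ccc([N+](=O)[O-])cc2)CC1c1ccc2c(c1)OCCO2` carries nitro in place of methoxy on an aromatic carbon with the rest of compound 2 unchanged. Among the measured compounds shown here, the only measured step bearing on this change also concerns a group on an aromatic carbon and is small (a 1.5-fold lower number from compound 1 to compound 2 (0.17 log units; within the scatter)) so no shift beyond the scatter is expected in this assay although this one step is thin evidence. The expected step (a 1.0-fold lower number from compound 2 to compound 3 (0.01 log units; within the scatter)) is therefore estimated to be minor. For compound 3 the estimated value is 45000 nM (expected range 18000 nM to 110000 nM).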

Compound 3, half-maximal inhibitory concentration: 70100 nM
Compound 3: the middle estimate sits 1.6-fold (0.19 log units) below what was measured; measured number inside the range.
By their numbers in this assay, from the lowest: compounds 2, 1 and 3 (each within the scatter of the next).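

At this place on the aromatic ring, para to a large group, nitro now stands alongside fluoro and methoxy, and this assay gives a 1.5-fold higher number from compound 2 to compound 3 (0.18 log units; within the scatter) and a 1.0-fold higher number from compound 1 to compound 3 (0.01 log units; within the scatter). Among the compounds shown here, all three groups therefore lie within the scatter of one another in this assay, which the single earlier step could not show. No measurement given here explains this result. Going by these compounds, whether an amine or a carboxylic acid on this carbon would also stay within the scatter remains open. So does the outcome of a longer chain elsewhere on the shared core.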